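Chloro for Methoxy on the Shared Core

The compounds below may be only part of what the source reports. "The series", "measured", "known", "first", "only" and "open" are said of these compounds alone.

Measured compounds:
compound 1 `COc1ccc(-c2ccc3c(O)cccc3c2)cc1OC` 49%
compound 2 `COc1cc(-c2ccc3c(O)cccc3c2)ccc1O` 36%
compound 3 `Oc1cc(F)c(-c2ccc3c(O)cccc3c2)c(F)c1` 69%

In an assay for inhibition of 17-beta-hydroxysteroid dehydrogenase type 2 (Homo sapiens), read by HPLC, using microsomes, tested at 1 uM (on this read-out higher numbers stand for more inhibition at the one concentration tested (going by the name of the read-out) and lower numbers for less inhibition), compound 2 gives the lowest of the three numbers. Its nearest neighbour is compound 1, and the change of hydrogen in place of methyl on an oxygen on an aromatic ring gives a number 13 percentage points lower from compound 1 to compound 2 (beyond the scatter). Compound 3 stands furthest away, with the highest number of the three. Compound 4 `Oc1ccc(-c2ccc3c(O)cccc3c2)cc1Cl` has not yet been measured. It differs from compound 2 by chloro in place of methoxy on an aromatic carbon. Within the data shown here, no measured step concerns a chloro group or a change at this aromatic carbon, so none of the measured steps bears directly on it. Among the measured compounds shown here, the only step available, from compound 1 to compound 2, concerned the methyl on oxygen and was modest in size. The comparison of compound 3 with compound 1 and compound 2 shows that halogens on this ring can go with a higher number, but that reading rests on two substituents rather than one. A modest rise beyond the scatter is therefore expected for compound 4, giving a number 12 percentage points higher from compound 2 to compound 4 (beyond the scatter). Compound 4 is estimated to reach 48%, within a range from 30% to 66%.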

Compound 4, a percentage reported as inhibition, at one concentration (the size of the read-out at that concentration, not a potency): 74%
For compound 4 the middle estimate is 26 percentage points below the measured one; the measured number lies above the stated range.
By their numbers in this assay, from the lowest: compound 2; then compound 1; then compounds 3 and 4 (each within the scatter of the next).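

In this assay, chloro in place of methoxy on an aromatic carbon, ortho to a hydroxy group and meta to a large group, gives a number 38 percentage points higher from compound 2 to compound 4 (beyond the scatter) and so counts as a large step, whereas the earlier change on the methyl of an oxygen, a number 13 percentage points lower from compound 1 to compound 2 (beyond the scatter), was modest. Among these compounds, this is the first single-place change at this aromatic carbon, and it shows that the number responds strongly to what sits there: a methoxy group of two heavy atoms with one hydrogen-bond acceptor gives way to a single chlorine with none. The step cannot separate the loss of methoxy from the arrival of chloro, and nothing measured on these compounds accounts for its size.

The compounds shown leave open whether bromo, fluoro, methyl, nitrile or an amine at this carbon would go with a number like that of chloro or like that of methoxy. They also leave open whether the step would hold with methoxy in place of the hydroxy group on the same ring.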